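The source may hold more compounds than are shown below. What is called first, only, known or untested is meant among the compounds shown, and "the series" means these compounds.

Measured compounds:
compound 1 `CC(C)c1onc(-c2c(Cl)cccc2Cl)c1COc1ccc(-c2nc3ccc(C(=O)O)cc3n2CC2CC2)cc1`: 2650 nM in an assay on HEK-293T cells for antagonist activity at vitamin D3 receptor (Homo sapiens), read by a luciferase reporter, with a stated time of 24 h; on this read-out lower numbers stand for stronger inhibition and higher numbers for weaker inhibition
compound 2 `CC(C)c1onc(-c2c(Cl)cccc2Cl)c1COc1ccc(-c2nc3ccc(C(=O)O)cc3n2-c2ccc(F)cc2)cc1`: 2410 nM in this assay
compound 3 `CC(C)c1onc(-c2c(Cl)cccc2Cl)c1COc1ccc(-c2nc3ccc(C(=O)O)cc3n2C2CCCC2)cc1`: 929 nM in this assay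

Compound 3 gives the lowest number of the three. The steps of a 2.9-fold lower number from compound 1 to compound 3 (0.46 log units; beyond the scatter) and a 2.6-fold lower number from compound 2 to compound 3 (0.41 log units; beyond the scatter) both lie beyond the scatter and are modest in size, whereas a 1.1-fold lower number from compound 1 to compound 2 (0.04 log units; within the scatter) is within the scatter, so compound 1 and compound 2 stand together and compound 3 apart from them.

Compound 4 `CC(C)c1onc(-c2c(Cl)cccc2Cl)c1COc1ccc(-c2nc3ccc(C(=O)O)cc3n2Cc2ccc(F)cc2)cc1` has not yet been measured. 4-fluorobenzyl in place of cyclopentyl on an aromatic nitrogen The two steps that bear on it are those into cyclopentyl: from cyclopropylmethyl, a 2.9-fold lower number from compound 1 to compound 3 (0.46 log units; beyond the scatter), and from 4-fluorophenyl, a 2.6-fold lower number from compound 2 to compound 3 (0.41 log units; beyond the scatter). Going by the values given here, the entering 4-fluorobenzyl combines features of both cyclopropylmethyl and 4-fluorophenyl, and no measured step carries a 4-fluorobenzyl, so its size cannot be read directly. Compound 4 is therefore expected to fall back toward the two weaker measured compounds, a modest rise in number of about a 1.9-fold higher number from compound 3 to compound 4 (0.29 log units; within the scatter), with a result within the scatter of the starting point not excluded. Compound 4 in this assay is estimated at 1800 nM, range 700 nM to 4500 nM.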

Compound 4, half-maximal inhibitory concentration: 1140 nM
For compound 4 the middle estimate is 1.6-fold (0.20 log units) above the measured one, and the stated range covers the measured number.
By their numbers in this assay, from the lowest: compounds 3 and 4 (each within the scatter of the next); then compounds 2 and 1 (each within the scatter of the next).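

In this assay, 4-fluorobenzyl on the aromatic nitrogen stands level with cyclopentyl (a 1.2-fold higher number from compound 3 to compound 4 (0.09 log units; within the scatter)), so among these compounds the lower group of numbers is not confined to a non-aromatic ring of carbon only: a six-membered aromatic ring of carbon only also reaches it when carried on a saturated chain carbon. The separation from the ring set directly on the aromatic nitrogen is the more informative comparison, as inserting that carbon between the same 4-fluorophenyl ring and the nitrogen gives a modest gain (a 2.1-fold lower number from compound 2 to compound 4 (0.33 log units; beyond the scatter)), and 4-fluorophenyl in place of cyclopropyl on the saturated chain carbon gives a step of similar size (a 2.3-fold lower number from compound 1 to compound 4 (0.37 log units; beyond the scatter)). No measurement on hand accounts for these differences.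

On these data alone, the contribution of the fluorine remains open, as does the outcome with a plain benzyl group or a longer chain such as 2-phenylethyl. Also open, as far as these compounds go, is whether a ring carrying an amine, such as piperidin-4-yl, on the aromatic nitrogen would fit the same narrow span of numbers or move well outside it.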